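Para-fluoro on the benzoyl ring: cytotoxicity working notes

A few compounds are considered here, and "the series" means these few. Any claim that something is new, unique, unknown or untested is made for them only; others in the source may bear on it.

Measured compounds in an ADME assay on MT4 cells (Homo sapiens) for cytotoxicity, read by MTT assay; a higher number here means that more compound is tolerated, a lower number that less compound is tolerated:
compound 1 `CCc1c(Cc2c(Cl)cccc2Cl)nc(SCC(=O)c2ccccc2)[nH]c1=O`: > 52000 nM, a limit of the assay
compound 2 `CCc1c(Cc2c(Cl)cccc2Cl)nc(SCC(=O)c2ccc(F)cc2)[nH]c1=O`: > 55000 nM, a limit of the assay
compound 3 `O=C(CSc1nc(Cc2c(F)cccc2Cl)cc(=O)[nH]1)c1ccccc1`: > 13000 nM, a limit of the assay

All three values recorded in this assay are limits, not numbers. Compound 1 gives a limit, (the limit of > 52000 nM in this assay, at which 1 of the 3 values shown sits). Compound 2 gives a limit, (the limit of > 55000 nM in this assay, at which 1 of the 3 values shown sits). Compound 3 gives a limit, (the limit of > 13000 nM in this assay, at which 1 of the 3 values shown sits). None of the three was toxic to the cells up to the highest concentration tested.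

Compound 2 differs from compound 1 by fluoro in place of hydrogen on an aromatic carbon. The corresponding step, a step that the two limits leave unreadable from compound 1 to compound 2, cannot be sized because both ends rest on limits, the limit of > 52000 nM in this assay, at which 1 of the 3 values shown sits, and (the limit of > 55000 nM in this assay, at which 1 of the 3 values shown sits).

Compound 4 `O=C(CSc1nc(Cc2c(F)cccc2Cl)cc(=O)[nH]1)c1ccc(F)cc1` is not yet measured. It differs from compound 3 by fluoro in place of hydrogen on an aromatic carbon, the same change as that from compound 1 to compound 2, at a place described in identical words. The difference between the core of compound 1 and the core of compound 3 is not broken down here.

For compound 4 in this assay the expected step is a step that the limit leaves unreadable from compound 3 to compound 4, a small one, which rests on a step that the two limits leave unreadable from compound 1 to compound 2 having left both ends at limits. Compound 4 is therefore estimated at 30000 nM, with the range 13000 nM to 80000 nM, and most likely the assay will again report only a limit.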

Compound 4, half-maximal cytotoxic concentration: > 61000 nM
Compound 4: a limit, no number; the forecaster's own chance of this, stated with the estimate: 85%; middle value at least 2.0-fold (0.30 log units) from the limit.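

In this assay compound 4 gives > 61000 nM, a limit of the assay. Compound 3 also gives only a limit, so no step can be read between compound 3 and compound 4. The compounds shown leave open whether fluoro in place of hydrogen on the aromatic carbon changes cytotoxicity at all, on either core, as every value shown remains a limit.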